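Trimethoxyphenyl series: cyclised analogue with a nitro-chloro aryl group

This account rests on a few compounds, and the source may have more. Where it says the series, first, only, none or still open, it means among the compounds named here.

Measured so far:
- compound 1, `COc1ccc(OC)c(C2OC(c3cc(OC)c(OC)c(OC)c3)=NN2C(C)=O)c1`: 0.4%
- compound 2, `COc1cccc(/C=N/NC(=O)c2cc(OC)c(OC)c(OC)c2)c1OC`: -0.1%
- compound 3, `COc1cc(C(=O)N/N=C/c2ccc(F)cc2)cc(OC)c1OC`: 50.9%

In a functional assay on BGC-823 cells (Homo sapiens) for antiproliferative activity, read by MTT assay, tested at 1 uM (a lower number here means a weaker effect, a higher number a stronger effect of the compound at the concentration tested), compound 1 gives 0.4%, the second highest of the three numbers; compound 2 lies within the scatter of it, while compound 3 stands well beyond the scatter above both. Compound 3 is built on a different, open-chain core, so nothing measured yet speaks to a change on the saturated ring carbon of the core of compound 1.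

Compound 4, `COc1cc(C2=NN(C(C)=O)C(c3ccc(Cl)c([N+](=O)[O-])c3)O2)cc(OC)c1OC`, differs from compound 1 by 4-chloro-3-nitrophenyl in place of 2,5-dimethoxyphenyl on a saturated ring carbon. For the measured compounds named here, with only one measured compound on this core, the step from compound 1 to compound 4 is expected to be small, upward if anything, and possibly not beyond the scatter: a number 9.6 percentage points higher from compound 1 to compound 4 (within the scatter). In this assay compound 4 is estimated at 10%, with a range from -5% to 35%.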

Compound 4, a percentage reported as inhibition, at one concentration (the size of the read-out at that concentration, not a potency): -2.3%
Compound 4: the middle estimate sits 12.3 percentage points above what was measured, within the range that was stated.
By their numbers in this assay, from the lowest: compounds 4, 2 and 1 (each within the scatter of the next); then compound 3.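

In this assay, for the compounds shown here, 4-chloro-3-nitrophenyl in place of 2,5-dimethoxyphenyl on the saturated ring carbon gives a number 2.7 percentage points lower from compound 1 to compound 4 (within the scatter) and so provides the first reading at this position. At this concentration, these two aryl groups are not told apart on the shared core. No measurement bears on why this is so.

From the compounds shown here alone, whether any other group on this carbon would raise the read-out stays open, for example an aminophenyl group, a carboxyphenyl group or a plain alkyl chain. Going by these compounds, whether compound 1 and compound 4 would separate at other concentrations also stays open.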